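The source may hold more compounds than are shown below. What is called first, only, known or untested is meant among the compounds shown, and "the series" means these compounds.

Measured compounds:
compound 1, `CCCCCC(CCCCC)n1ccc2cc(/C(C)=C/C(=O)Nc3ccccc3OCCCC(=O)O)ccc21` — 25 nM
compound 2, `C/C(=C\C(=O)Nc1ccccc1OCCCC(=O)O)c1ccc2c(ccn2C(C(C)C)C(C)C)c1` — 14 nM
compound 3, `C/C(=C\C(=O)Nc1ccccc1OCCCC(=O)O)c1ccc2c(ccn2Cc2ccccc2C)c1` — 69 nM

All three were tested in an assay on Prostate gland for inhibition of steroid 5-alpha-reductase (Rattus norvegicus); a lower number here means a stronger inhibitor, a higher number a weaker inhibitor. Compound 3 stands at the highest of the three numbers, that is, as the weakest inhibitor of the set: there is a 2.8-fold higher number from compound 1 to compound 3 (0.44 log units; beyond the scatter) and a 4.9-fold higher number from compound 2 to compound 3 (0.69 log units; beyond the scatter). Compound 1 and compound 2 lie within the scatter of each other, since there is only a 1.8-fold lower number from compound 1 to compound 2 (0.25 log units; within the scatter).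

Compound 4, `C/C(=C\C(=O)Nc1ccccc1OCCCC(=O)O)c1ccc2c(ccn2Cc2ccc(C)cc2)c1`, is the next compound. It differs from compound 3 only in 4-methylphenyl in place of 2-methylphenyl on a saturated chain carbon bound to an aromatic nitrogen; the two have the same atoms, joined differently.

Among the measured compounds shown here, none of the measured steps speaks directly to this change. Each of them replaces the whole group on the aromatic nitrogen, exchanging a branched alkyl group for another or for a 2-methylbenzyl group; none moves the methyl from one position of a benzyl ring to another. For the measured compounds named here, the measured steps therefore give no direction for the step from compound 3 to compound 4, and the expectation in this assay is for no step beyond the scatter, a 1.2-fold lower number from compound 3 to compound 4 (0.06 log units; within the scatter), with the range kept wide for want of a precedent. Compound 4 is accordingly estimated at 60 nM, within 25 nM to 150 nM.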

Compound 4, half-maximal inhibitory concentration: 88 nM
Beside the measured number, compound 4's estimate is 1.5-fold (0.17 log units) below it, within the range that was stated.
By their numbers in this assay, from the lowest: compounds 2 and 1 (each within the scatter of the next); then compounds 3 and 4 (each within the scatter of the next).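

Moving the methyl group from the 2-methylphenyl to the 4-methylphenyl arrangement on a saturated chain carbon bound to an aromatic nitrogen gives a 1.3-fold higher number from compound 3 to compound 4 (0.11 log units; within the scatter) in this assay, so this change, which the earlier compounds did not cover, does not separate the two isomers. Compound 4 also stays apart from the compounds carrying branched alkyl groups on the aromatic nitrogen, with a 6.3-fold higher number from compound 2 to compound 4 (0.80 log units; beyond the scatter) for 1-isopropyl-2-methylpropyl and a 3.5-fold higher number from compound 1 to compound 4 (0.55 log units; beyond the scatter) for 1-pentylhexyl, so the gap first seen with the 2-methylbenzyl group of compound 3 holds for the 4-methylbenzyl group as well. No supporting evidence is available to account for this result.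

The compounds shown leave open whether a plain benzyl group, or a 4-chlorobenzyl or 4-methoxybenzyl group, would fall with compound 3 and compound 4 in this assay. They also leave open whether a cyclohexylmethyl group on the same nitrogen would fall with those two compounds or with compound 1 and compound 2.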